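The compounds below may be only part of what the source reports. "The series", "measured", "known", "first", "only" and "open" are said of these compounds alone.

For the measured compounds named here, in an ADME assay on microsomes from liver (Homo sapiens) for metabolic stability (a lower number here means that the compound disappears faster, a higher number that the compound lasts longer), compound 3 `CC(C)C(Nc1nccs1)c1ccc(-c2ccc3cccc(F)c3c2)[nH]c1=O` gives 0.17 h, the lowest number so far. Compound 1 `CCC(CC)(c1nnc[nH]1)c1ccc(-c2ccc3cc(F)cc(F)c3c2)[nH]c1=O` gives 1.76 h, a gap well beyond the usual scatter of repeated measurements. Compound 2 `CCn1ncc2c(F)cc(-c3ccc(C(CC)(CC)c4nnc(C)[nH]4)c(=O)[nH]3)cc21` reads > 3 h, which is a limit and not a number.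

Compound 4 `CC(C)C(CC(N)=O)c1ccc(-c2ccc3cccc(F)c3c2)[nH]c1=O` differs from compound 3 in one place: carbamoylmethyl in place of (1,3-thiazol-2-yl)amino on a saturated chain carbon bound to an aromatic carbon and a saturated chain carbon. Carbamoylmethyl stands in place of (1,3-thiazol-2-yl)amino on a saturated chain carbon bound to an aromatic carbon and a saturated chain carbon. Going by the values given here, no measured pair shows this change, so the expectation is loose. Since compound 3 sits at 0.17 h, a moderate rise beyond the scatter is expected in this assay. The estimated step is a 3.5-fold higher number from compound 3 to compound 4 (0.55 log units; beyond the scatter). The half-life expected for compound 4 is 0.6 h, within an estimated range of 0.2 h to 1.8 h.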

Compound 4, half-life: < 0.0667 h
Compound 4 ended at the assay's limit; the forecaster's own chance of this, stated with the estimate: 3%; at least 8.9-fold (0.95 log units) between middle value and limit.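

Replacing (1,3-thiazol-2-yl)amino with carbamoylmethyl on this saturated chain carbon gives an at least 2.5-fold lower number from compound 3 to compound 4 (0.40 log units; beyond the scatter) in this assay, so the half-life depends on the group at this position. A short half-life here also does not require the thiazole ring. The value of compound 4, < 0.0667 h, is a limit of the assay and not a number, so the step gives a direction but no exact size.

Going by these compounds, whether an amine or a carboxylic acid on this carbon would give a longer half-life remains open. The reason for the drop also remains open, since compound 1 and compound 2 each differ from compound 3 in more than one place.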